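Hydrogen for methyl in compound 1: working notes

A few compounds are considered here, and "the series" means these few. Any claim that something is new, unique, unknown or untested is made for them only; others in the source may bear on it.

Values from an ADME assay on MT4 cells (Homo sapiens) for cytotoxicity, read by MTT assay, with a stated time of 96 h (on this read-out lower numbers stand for higher toxicity in this test and higher numbers for lower toxicity in this test), so far
- compound 1 (`Cc1ccc(/N=N/N(C)c2ccccc2)cc1`) gives 45000 nM
- compound 2 (`c1ccc(/N=N/c2ccc(NC[C@@H]3CCCN4CCCC[C@H]34)c3c2CCCC3)cc1`) gives 100000 nM

Compound 1 at 45000 nM holds the lower of the two numbers, and compound 2 at 100000 nM lies higher, a gap beyond the scatter. Compound 3 (`CN(/N=N/c1ccccc1)c1ccccc1`) is still unmeasured. It departs from compound 1 by hydrogen in place of methyl on an aromatic carbon. Going by the values given here, no measured pair shows this change. The expectation in this assay is no step beyond the scatter, with an estimated 1.2-fold higher number from compound 1 to compound 3 (0.09 log units; within the scatter) pointing slightly upward. Compound 3 is estimated at 55000 nM (expected range 25000 nM to 100000 nM).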

Compound 3, half-maximal cytotoxic concentration: 55000 nM
Estimate against measurement, compound 3: no gap at the digits printed; the measured number falls inside the stated range.
By their numbers in this assay, from the lowest: compounds 1, 3 and 2 (each within the scatter of the next, the first and the last beyond it).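

In this assay, hydrogen in place of methyl on an aromatic carbon, para to a large group, gives a 1.2-fold higher number from compound 1 to compound 3 (0.09 log units; within the scatter). Going by these compounds alone, this is the first reading of this change, and it shows that on this core the methyl can be exchanged for hydrogen without a step beyond the scatter. No measured property of these compounds offers an account of this result.

Open, going by these compounds, is how larger or different groups at this place, such as a methoxy group, a chlorine atom or an amine, would read in this assay. Also open, on these data alone, is whether the same exchange gives a similar step on another core.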